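The source may report more compounds than this note shows. Statements on the series, on what has been measured and on what is new or still open speak of the compounds shown alone.

In a functional assay on HOP-92 cells (Homo sapiens) for cytotoxicity, read by sulforhodamine B assay, with a stated time of 48 h (a lower number here means a stronger inhibitor of growth, a higher number a weaker inhibitor of growth), three compounds of one shared core have been measured. Compound 1 `CC1=C(C(=O)Nc2ccc(F)c(Cl)c2)C(c2ccccc2Cl)NC(=S)N1` gives 50100 nM in this assay. Compound 2 `CC1=C(C(=O)Nc2ccc(F)c(Cl)c2)C(c2cccc(Oc3ccccc3)c2)NC(=S)N1` gives 20900 nM in this assay, and compound 3 `CC1=C(C(=O)Nc2ccc(Cl)c(Cl)c2)C(c2cccc(Oc3ccccc3)c2)NC(=S)N1` gives 13200 nM in this assay. Of the three numbers, that of compound 1 is the highest; the difference between the core of compound 1 and the core of compound 2 is not broken down here, and their two values simply show compound 2 standing a good way lower than compound 1.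

Compound 2 and compound 3 differ in one place only, (chloro in place of fluoro on an aromatic carbon), and the step between them is a 1.6-fold lower number from compound 2 to compound 3 (0.20 log units; within the scatter).

The unmeasured compound 4 `CC1=C(C(=O)Nc2ccc(Cl)c(Cl)c2)C(c2ccccc2Cl)NC(=S)N1` carries the same change relative to compound 1: chloro in place of fluoro on an aromatic carbon. The place of the change is described in the same words for both pairs, so the change is taken as the same, made on the second core in the series.

For compound 4 the expectation rests on compound 2 and compound 3, whose step a 1.6-fold lower number from compound 2 to compound 3 (0.20 log units; within the scatter) stayed inside the usual scatter; the step from compound 1 to compound 4 is therefore expected to be of about the same size, a 1.6-fold lower number from compound 1 to compound 4 (0.19 log units; within the scatter), in this assay. On that basis compound 4 is estimated at 32000 nM in this assay, with a likely range from 15000 nM to 68000 nM.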

Compound 4, concentration for 50% growth inhibition: 1200 nM
For compound 4 the middle estimate is 27-fold (1.43 log units) above the measured one, and the stated range ends above it.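

Putting chloro in place of fluoro on the aromatic carbon, which turns 3-chloro-4-fluorophenyl into 3,4-dichlorophenyl, gives a 42-fold lower number from compound 1 to compound 4 (1.62 log units; beyond the scatter) in this assay and so makes a large difference on this core, while the same change made little measurable difference on the other core. The two steps do not agree, and in this series the size of the change did not carry over from one core to the other: the same change on two cores in this assay, a 1.6-fold lower number (0.20 log units; within the scatter) from compound 2 to compound 3 and a 42-fold lower number (1.62 log units; beyond the scatter) from compound 1 to compound 4, 26-fold (1.42 log units) apart, beyond the scatter of two such steps. Going by these compounds alone, this shows that a step read on one core is a poor guide to the step on the other, but it does not show what in the two cores sets them apart, and with only two pairs it cannot tell which of the two sizes is the more typical for this change or how the change would behave on any further core.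

The compounds shown leave open whether bromo or methyl in place of the fluoro would follow the large step or the small one. They also leave open whether a third core, for instance one carrying a methoxy group or an amine on the other aromatic ring, would side with either pair or give a step of its own.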